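A few compounds are considered here, and "the series" means these few. Any claim that something is new, unique, unknown or untested is made for them only; others in the source may bear on it.

In a functional assay on PANC-1 cells (Homo sapiens) for cytotoxicity, read by MTT assay, with a stated time of 68 h (a higher number here means a weaker inhibitor, a lower number a stronger inhibitor), compound 1 `O=C(/C=C/c1cccc(OCc2ccccc2)c1)c1ccc([N+](=O)[O-])cc1` gives 25400 nM and compound 2 `O=C(/C=C/c1cccc(OCc2ccccc2)c1)c1ccc(Cl)cc1Cl` gives 27200 nM. Compound 3 `O=C(/C=C/c1cccc(OCc2ccccc2)c1)c1ccccc1Br` gives 61200 nM, the highest number of the three, which makes it the weakest inhibitor here. Compound 4 `O=C(/C=C/c1cccc(OCc2ccccc2)c1)c1cccc(Br)c1` is still unmeasured. It carries 3-bromophenyl in place of 2-bromophenyl on a carbonyl carbon. Going by the values given here, no measured step shows this change itself. The closest evidence is two modest steps, a 2.4-fold higher number from compound 1 to compound 3 (0.38 log units; beyond the scatter) and a 2.3-fold higher number from compound 2 to compound 3 (0.35 log units; beyond the scatter), while the third is a 1.1-fold higher number from compound 1 to compound 2 (0.03 log units; within the scatter). A step towards a lower number in this assay is therefore expected, no larger than those modest ones. The estimated step is a 1.7-fold lower number from compound 3 to compound 4 (0.23 log units; within the scatter). Compound 4 is expected at 36000 nM, with an estimated range of 15000 nM to 75000 nM.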

Compound 4, half-maximal inhibitory concentration: 6400 nM
Compound 4: the middle estimate sits 5.6-fold (0.75 log units) above what was measured; the whole stated range lies above it.
By their numbers in this assay, from the lowest: compound 4; then compounds 1 and 2 (each within the scatter of the next); then compound 3.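

Swapping 2-bromophenyl for 3-bromophenyl on the carbonyl carbon keeps the same atoms, joined differently, yet in this assay it gives a 9.6-fold lower number from compound 3 to compound 4 (0.98 log units; beyond the scatter), a larger step than any seen among the earlier compounds. The 3-bromophenyl group also gives lower numbers than the other two groups, with a 4.3-fold lower number from compound 2 to compound 4 (0.63 log units; beyond the scatter) and a 4.0-fold lower number from compound 1 to compound 4 (0.60 log units; beyond the scatter). Nothing measured here accounts for these differences. The compounds shown leave open whether a phenyl ring carrying an amine or a carboxylic acid at this place would give a lower number still.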